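Cytotoxicity Expected for a Butylamino Analogue of Compound 1

A few compounds are considered here, and "the series" means these few. Any claim that something is new, unique, unknown or untested is made for them only; others in the source may bear on it.

Compound 1 `CCCSc1nc(N)nc2c1ncn2/C=C1/CC1(CO)CO` gives in an ADME assay on Akata cells (Homo sapiens) for cytotoxicity, with a stated time of 7 days (a higher number here means that more compound is tolerated, a lower number that less compound is tolerated), only the limit > 20000 nM.
Compound 2 `Nc1nc(N2CCCC2)c2ncn(/C=C3/CC3(CO)CO)c2n1` gives in this assay only the limit > 24000 nM.
Compound 3 `CSc1nc(N)nc2c1ncn2/C=C1/CC1(CO)CO` gives in this assay only the limit > 20000 nM.

Compound 1 therefore stands at a limit, not at a number, and the same holds for the other two values: the limit of > 20000 nM in this assay, at which 2 of the 3 values shown sit, and (the limit of > 24000 nM in this assay, at which 1 of the 3 values shown sits). Compound 4 `CCCCNc1nc(N)nc2c1ncn2/C=C1/CC1(CO)CO` differs from compound 1 in one place: butylamino in place of propylsulfanyl on an aromatic carbon. The two measured steps that start from compound 1, a step that the two limits leave unreadable from compound 1 to compound 2 and a step that the two limits leave unreadable from compound 1 to compound 3, both run between limits, so their size cannot be read, and no step beyond the scatter is expected in this assay either way. Compound 4 is thus expected to give about 30000 nM, within 10000 nM to 100000 nM, most likely again as a limit, so that the expected step is a step that the limit leaves unreadable from compound 1 to compound 4.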

Compound 4, half-maximal cytotoxic concentration: > 24000 nM
Compound 4 ended at the assay's limit; the forecaster's own chance of this, stated with the estimate: 80%; the middle value lies beyond the limit too.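

The steps from compound 1, compound 2 and compound 3 to compound 4 all run between limits, so none can be read. The compounds shown leave open at what concentration any of them turns cytotoxic in this assay.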